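The source may report more compounds than this note shows. Statements on the series, on what has been measured and on what is new or still open speak of the compounds shown alone.

Measured so far:
- Compound 1 `COc1ccc(-c2c(Nc3cc(OC)c(OC)c(OC)c3)c3ccc(O)cc3oc2=O)cc1`: 49700 nM
- Compound 2 `COc1ccc(Nc2c(C(=O)C(F)(F)F)c(=O)oc3cc(OC)ccc23)cc1`: 38400 nM
- Compound 3 `COc1ccc(Nc2c(C(=O)C(F)(F)F)c(=O)oc3ccc(OC)cc23)cc1`: > 100000 nM

In a functional assay on HepG2 cells (Homo sapiens) for antiproliferative activity, read by MTT assay, with a stated time of 48 h (on this read-out lower numbers stand for stronger inhibition and higher numbers for weaker inhibition), compound 1 gives 49700 nM and compound 2 gives 38400 nM. These two values lie within the usual scatter of each other. Compound 3 is recorded as > 100000 nM, which is a limit of the assay and not a number. Its true potency is therefore unknown, and it stands alone in this small set in having no exact value.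

Compound 4 `COc1ccc2oc(=O)c(C(=O)C(F)(F)F)c(Nc3ccc(F)cc3)c2c1` keeps the rest of compound 3 and changes one group: fluoro in place of methoxy on an aromatic carbon, para to a large group, so that 4-methoxyphenyl becomes 4-fluorophenyl (fluoro in place of methoxy on an aromatic carbon). For the measured compounds named here, no measured pair here isolates this change, so the expectation is loose. Compound 2 at 38400 nM shows that a close relative of compound 3 can give a real number in this assay, so a modest move toward stronger inhibition seems possible, though no change beyond the scatter could also be seen. The expected step runs an at least 1.5-fold lower number from compound 3 to compound 4 (0.18 log units; that floor lies within the scatter). For compound 4 the estimated value is 65000 nM, with an expected range from 20000 nM to 150000 nM.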

Compound 4, half-maximal inhibitory concentration: > 100000 nM
Compound 4: a limit, no number; the forecaster's own chance of this, stated with the estimate: 40%; middle value at least 1.5-fold (0.18 log units) away from the limit.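

Compound 4 gives > 100000 nM in this assay, which is a limit of the assay and not a number. No step can be read between compound 3 and compound 4, because both stop at the same limit: the limit of > 100000 nM in this assay, at which 2 of the 4 values shown sit. Going by these compounds, whether fluoro in place of methoxy on an aromatic carbon shifts inhibition at all stays open.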